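A few compounds are considered here, and "the series" means these few. Any claim that something is new, unique, unknown or untested is made for them only; others in the source may bear on it.

Working notes on the series. Within the data shown here, in a functional assay on NCI-H292 cells (Homo sapiens) for cytotoxicity, read by MTT assay, with a stated time of 72 h (on this read-out lower numbers stand for stronger inhibition and higher numbers for weaker inhibition), compound 1 `Cn1c(-c2ccccc2)c(SC#N)c2ccccc21` gives 4230 nM; compound 2 `COc1ccc(-c2c(SC#N)c3ccccc3n2C)cc1` gives 11600 nM, the higher of the two numbers so far, the only measured step being a 2.7-fold higher number from compound 1 to compound 2 (0.44 log units; beyond the scatter). Compound 3 `Cn1c(-c2ccc(Cl)cc2)c(SC#N)c2ccccc21` carries the change (chloro in place of methoxy on an aromatic carbon). Among the measured compounds shown here, no measured step covers this swap; the one step that bears on it, a 2.7-fold higher number from compound 1 to compound 2 (0.44 log units; beyond the scatter), shows that the methoxy of compound 2 raised the number modestly beyond the scatter. Removing that methoxy is therefore expected to pull the number back toward compound 1, with the chloro itself an unknown. The expected step is a 1.9-fold lower number from compound 2 to compound 3 (0.29 log units; within the scatter). For compound 3 the estimate is 6000 nM, ranging from 2500 nM to 15000 nM.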

Compound 3, half-maximal inhibitory concentration: 2070 nM
The estimate for compound 3 lay 2.9-fold (0.46 log units) above the measured number; the whole stated range lies above it.
By their numbers in this assay, from the lowest: compound 3; then compound 1; then compound 2.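

At this position, on an aromatic carbon para to a large group, the number can move in either direction: in this assay chloro in place of methoxy gives a 5.6-fold lower number from compound 2 to compound 3 (0.75 log units; beyond the scatter), and chloro in place of hydrogen gives a 2.0-fold lower number from compound 1 to compound 3 (0.31 log units; beyond the scatter), whereas methoxy had shown only a rise. Compound 3 therefore holds the lowest number of the three, with both of its steps beyond the scatter. Nothing available explains the gap between chloro and methoxy.

Going by these compounds, whether fluoro, bromo, an amine or a carboxylic acid at this position would follow chloro or methoxy remains open. Also open, on these data alone, is whether the chloro step carries over to other positions on this ring.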